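Swapping chloro for fluoro on compound 2

The source may hold more compounds than are shown below. What is called first, only, known or untested is meant among the compounds shown, and "the series" means these compounds.

In a functional assay on HL-60 cells (Homo sapiens) for inhibition, read by CCK-8 assay, with a stated time of 48 h, tested at 20 uM (a higher number here means more inhibition of growth at the concentration tested, a lower number less inhibition of growth), compound 1 (`N#C/C(=C\c1ccccc1OS(=O)(=O)c1ccc(F)cc1)C(=O)Nc1nnc(Cc2cccc3ccccc23)s1`) gives 12%. Compound 2 (`Cc1ccc(Cc2nnc(NC(=O)/C(C#N)=C/c3ccccc3OS(=O)(=O)c3ccc(Cl)cc3)s2)cc1`) gives 38%, the higher of the two numbers, with a gap beyond the usual scatter. These two compounds differ in more than one place, so their gap cannot be pinned on any single change. Compound 3 (`Cc1ccc(Cc2nnc(NC(=O)/C(C#N)=C/c3ccccc3OS(=O)(=O)c3ccc(F)cc3)s2)cc1`) comes from compound 2 by one swap, fluoro in place of chloro on an aromatic carbon. Within the data shown here, no measured pair isolates this swap, so only a slight drop, within the scatter, is expected in this assay. The estimated step is a number 8 percentage points lower from compound 2 to compound 3 (within the scatter). Compound 3 is expected to give 30%, within an estimated range of 12% to 50%.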

Compound 3, percent growth inhibition at one concentration: 11%
The estimate for compound 3 lay 19 percentage points above the measured number; measured number outside the range, below it.
By their numbers in this assay, from the lowest: compounds 3 and 1 (each within the scatter of the next); then compound 2.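

In this assay, this one atom on the sulfonyl-bearing ring matters: fluoro in place of chloro gives a number 27 percentage points lower from compound 2 to compound 3 (beyond the scatter). With fluoro on that ring, 4-methylphenyl in place of naphthalen-1-yl gives a number 1 percentage points lower from compound 1 to compound 3 (within the scatter), so these two groups cannot be told apart in this setting. Chloro is therefore the change that counts for compound 2, at least against fluoro.

Nothing shown gives a reason for the chloro step. Open questions are how bromo or methoxy would behave at this place, and whether naphthalen-1-yl would match 4-methylphenyl alongside chloro.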